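The compounds below may be only part of what the source reports. "The series", "measured", "known", "first", "only" and "open" are said of these compounds alone.

In an assay on isolated protein for inhibition of Amine oxidase [flavin-containing] A (Homo sapiens), read by fluorescence, with a stated time of 15 min (a higher number here means a weaker inhibitor, a lower number a stronger inhibitor), compound 1 `COc1ccc(/C=C/c2cc(OC)cc(OC)c2/C=C/C(=O)c2cc3ccccc3oc2=O)cc1` gives 41700 nM, compound 2 `CCOc1ccc2cc(C(=O)/C=C/c3c(/C=C/c4ccc(OC)cc4)cc(OC)cc3OC)c(=O)oc2c1` gives 7070 nM, and compound 3 `COc1ccc(/C=C/c2cc(OC)cc(OC)c2/C=C/C(=O)c2cc3ccc(Br)cc3oc2=O)cc1` gives 3010 nM. Compound 3 has the lowest number of the three; the gaps to the others are a 2.3-fold lower number from compound 2 to compound 3 (0.37 log units; beyond the scatter) and a 14-fold lower number from compound 1 to compound 3 (1.14 log units; beyond the scatter). Compound 4 `COc1ccc(/C=C/c2cc(OC)cc(OC)c2/C=C/C(=O)c2cc3ccc(Cl)cc3oc2=O)cc1` differs from compound 3 by chloro in place of bromo on an aromatic carbon. Going by the values given here, no measured step exchanges one halogen for another. The steps that touch this carbon are a 14-fold lower number from compound 1 to compound 3 (1.14 log units; beyond the scatter), a large gain, and a 2.3-fold lower number from compound 2 to compound 3 (0.37 log units; beyond the scatter), a modest one; both show that a substituent here lowers the number, but neither separates chloro from bromo, so the step in this assay is expected to be small, close to the scatter. For compound 4 the estimate is 4000 nM, range 1800 nM to 9000 nM, meaning an expected 1.3-fold higher number from compound 3 to compound 4 (0.12 log units; within the scatter).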

Compound 4, half-maximal inhibitory concentration: > 60000 nM
Compound 4: no number, only a limit; the forecaster's own chance of this, stated with the estimate: 2%; at least 15-fold (1.17 log units) between middle value and limit.
By their numbers in this assay, from the lowest: compound 3; then compound 2; then compound 1. At a limit, above all of these: compound 4.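

In this assay, the two halogens at this carbon are not interchangeable: an at least 19-fold higher number from compound 3 to compound 4 (1.29 log units; beyond the scatter), and an at least 8.4-fold higher number from compound 2 to compound 4 (0.92 log units; beyond the scatter). Chloro shows no gain over hydrogen, an at least 1.4-fold higher number from compound 1 to compound 4 (0.15 log units; that floor lies within the scatter), so the lowering seen with bromo and ethoxy does not extend to every substituent here. Compound 4 stands only as a limit of the assay: the limit of > 60000 nM in this assay, at which 1 of the 4 values shown sits.

On these data alone, whether fluoro, iodo, methoxy or an amine at this carbon would behave like bromo or like chloro stays open. As far as these compounds go, how far compound 4 lies beyond its limit also stays open.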